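Swapping the Amine Substituent on a Shared Core

This account rests on a few compounds, and the source may have more. Where it says the series, first, only, none or still open, it means among the compounds named here.

Compound 3, `CCCCOc1ccc(-c2nc3ncccn3c2Nc2ccc(F)cc2)cc1`, carries a 4-fluorophenyl on a nitrogen on an aromatic ring of the shared core. In a toxicity assay on A549 cells (Homo sapiens) for cytotoxicity, read by luminescence and CellTiter-Glo, with a stated time of 48 h (a higher number here means that more compound is tolerated, a lower number that less compound is tolerated), compound 3 gives only a limit of the assay, > 100000 nM. Two other compounds with the same core frame this position. Compound 1, `CCCCOc1ccc(-c2nc3ncccn3c2NC2CCCCCC2)cc1`, has a cycloheptyl on that nitrogen, and in this assay compound 1 gives 26000 nM. Compound 2, `CCCCOc1ccc(-c2nc3ncccn3c2N)cc1`, has only hydrogen there; in this assay compound 2 reaches a limit of the assay, > 100000 nM. The steps of an at least 3.8-fold higher number from compound 1 to compound 2 (0.58 log units; beyond the scatter) and an at least 3.8-fold higher number from compound 1 to compound 3 (0.58 log units; beyond the scatter) both run toward that ceiling, while the step that the two limits leave unreadable from compound 2 to compound 3 cannot be sized because the limit of > 100000 nM in this assay, at which 2 of the 3 values shown sit, caps both of its ends.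

Compound 4, `CCCCOc1ccc(-c2nc3ncccn3c2NCc2ccc(OC)cc2)cc1`, differs from compound 3 by 4-methoxybenzyl in place of 4-fluorophenyl on a nitrogen on an aromatic ring. Within the data shown here, no measured step makes this exact change; the nearest, an at least 3.8-fold higher number from compound 1 to compound 3 (0.58 log units; beyond the scatter), showed that replacing cycloheptyl by 4-fluorophenyl on this nitrogen moved the number up to the limit. For compound 4 a small step, or none beyond the scatter, is expected: an at least 1.2-fold lower number from compound 3 to compound 4 (0.09 log units; that floor lies within the scatter). In this assay compound 4 is therefore estimated at 80000 nM, within 25000 nM to 150000 nM, with a fair chance that only a limit is reported again.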

Compound 4, half-maximal cytotoxic concentration: 55000 nM
Compound 4: the middle estimate sits 1.5-fold (0.16 log units) above what was measured, within the range that was stated.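

A second group on this nitrogen now gives a number rather than a limit: in this assay compound 4 gives 55000 nM. Measured against cycloheptyl, the change gives a 2.1-fold higher number from compound 1 to compound 4 (0.33 log units; beyond the scatter), so 4-methoxybenzyl is modestly better tolerated than cycloheptyl on the shared core, while still giving a reading in this range. The other two new steps, an at least 1.8-fold lower number from compound 3 to compound 4 (0.25 log units; that floor lies within the scatter) and an at least 1.8-fold lower number from compound 2 to compound 4 (0.25 log units; that floor lies within the scatter), are only floors that lie within the scatter, so they do not establish a real drop from either compound, and both start from the same ceiling: the limit of > 100000 nM in this assay, at which 2 of the 4 values shown sit.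

The step from 4-fluorophenyl to 4-methoxybenzyl alters both the ring's substituent and the ring's link to the nitrogen, and a plain benzyl or a 4-fluorobenzyl group on this nitrogen would be needed to tell those two changes apart. A cyclohexyl group or an open butyl chain in the same place would help show whether the tolerated amount tracks the kind of group, ring or chain, that sits on this nitrogen.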